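The source may report more compounds than this note shows. Statements on the series, on what has been measured and on what is new or still open speak of the compounds shown alone.

Of the compounds shown here, two have been measured in a functional assay on WiDr cells (Homo sapiens) for cytotoxicity, read by sulforhodamine B assay, with a stated time of 72 h; a higher number here means a weaker inhibitor, a lower number a stronger inhibitor. Compound 1 `O=C(O)/C=C/c1cc(O)c(O)c(O)c1` gives 114000 nM in this assay. For the measured compounds named here, compound 2 `CCCCCCNC(=O)/C=C/c1ccc(O)c(O)c1` gives 35500 nM, the lowest of the two numbers, with compound 1 showing a number beyond the scatter above it; the two differ in more than one place, so no single step links them. Compound 3 `CCCCCCNC(=O)/C=C/c1cc(O)c(O)c(O)c1` is not yet measured. Compared with compound 2, it carries hydroxy in place of hydrogen on an aromatic carbon. Going by the values given here, no measured pair isolates this change, so the step from compound 2 to compound 3 is expected to be small, a 1.1-fold higher number from compound 2 to compound 3 (0.05 log units; within the scatter), likely within the scatter. Compound 3 is estimated at 40000 nM, in a range from 15000 nM to 110000 nM.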

Compound 3, half-maximal inhibitory concentration: 37700 nM
Estimate against measurement, compound 3: 1.1-fold (0.03 log units) above; measured number inside the range.
By their numbers in this assay, from the lowest: compounds 2 and 3 (each within the scatter of the next); then compound 1.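

In this assay, for the compounds shown here, the hydroxy in place of hydrogen on this aromatic carbon, ortho to a hydroxy group, gives a 1.1-fold higher number from compound 2 to compound 3 (0.03 log units; within the scatter) and this is the first single change that can be read directly. At this position, then, the extra hydroxy leaves the number within the scatter, in this one pair only. As far as these compounds go, whether an amine or a carboxylic acid on this same carbon would behave alike remains open, as does the effect of a longer chain. No measured evidence here speaks to the reason for this result.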